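Swapping Bromo for Methoxy on a Second Sugar-Bearing Core

A few compounds are considered here, and "the series" means these few. Any claim that something is new, unique, unknown or untested is made for them only; others in the source may bear on it.

Of the compounds shown here, three have been measured in an ADME assay on Vero cells (Chlorocebus sabaeus) for cytotoxicity, read by fluorescence and resazurin assay, with a stated time of 3 days; on this read-out lower numbers stand for higher toxicity in this test and higher numbers for lower toxicity in this test. Compound 1, `CC(=O)C[C@H]1O[C@@H](On2cc(CN3C(=O)/C(=N\Nc4ccc(Br)cc4)c4ccccc43)nn2)[C@H](OC(C)=O)[C@@H](OC(C)=O)[C@@H]1OC(C)=O`, gives 116000 nM. Compound 2, `COc1ccc(N/N=C2\C(=O)N(Cc3cn(O[C@@H]4O[C@H](CC(C)=O)[C@@H](OC(C)=O)[C@H](OC(C)=O)[C@H]4OC(C)=O)nn3)c3ccccc32)cc1`, differs from compound 1 in one place, (methoxy in place of bromo on an aromatic carbon), and in this assay compound 2 gives 95300 nM. The step of a 1.2-fold lower number from compound 1 to compound 2 (0.09 log units; within the scatter) is therefore small and within the scatter of repeated measurements, so the two numbers cannot be told apart.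

Compound 3, `CC1(C)O[C@H]2O[C@H](Cn3cc(CN4C(=O)/C(=N\Nc5ccc(Br)cc5)c5ccccc54)nn3)[C@H](O)[C@H]2O1`, carries the same bromo-bearing arm on a different core; the difference between the two cores is not broken down here. In this assay compound 3 gives 72900 nM, and its numbers and those of compound 1 and compound 2 all lie within the scatter of one another.

Compound 4, `COc1ccc(N/N=C2\C(=O)N(Cc3cn(C[C@H]4O[C@@H]5OC(C)(C)O[C@@H]5[C@H]4O)nn3)c3ccccc32)cc1`, stands to compound 3 as compound 2 stands to compound 1: the change is methoxy in place of bromo on an aromatic carbon. The same change has already been seen once, between compound 1 and compound 2, where it moved the number hardly at all. On that basis the step of a 1.2-fold lower number from compound 3 to compound 4 (0.08 log units; within the scatter) is expected to be of the same small size. Since compound 3 gives 72900 nM, the value expected for compound 4 in this assay is 60000 nM, with a likely range from 30000 nM to 120000 nM.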

Compound 4, half-maximal cytotoxic concentration: 74500 nM
Estimate against measurement, compound 4: 1.2-fold (0.09 log units) below; the measured number falls inside the stated range.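

In this assay, methoxy in place of bromo on an aromatic carbon gives a 1.0-fold higher number from compound 3 to compound 4 (0.01 log units; within the scatter), so on this second core the swap again leaves no mark that can be read in the number. Set side by side, the two steps cannot be told apart: the same change on two cores in this assay, a 1.2-fold lower number (0.09 log units; within the scatter) from compound 1 to compound 2 and a 1.0-fold higher number (0.01 log units; within the scatter) from compound 3 to compound 4, 1.2-fold (0.09 log units) apart, within the scatter of two such steps. This shows that, for these two pairs and in this one test of toxicity to cells, the change carried from one core to the other without any detectable difference, but it does not show that the same would hold on a third core or in another kind of test, and two small steps say nothing about the reason for the result.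

As far as these compounds go, what happens with other groups at the same place on the ring remains open, for instance whether an amine, a carboxylic acid or a nitrile in place of bromo would also leave the number within the scatter on both cores. From the compounds shown here alone, it is also open whether a longer chain, such as ethoxy or butoxy in place of methoxy, would behave in the same way on the two cores.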